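Swapping Chloro for Bromo in Compound 1

The source may report more compounds than this note shows. Statements on the series, on what has been measured and on what is new or still open speak of the compounds shown alone.

Measured compounds in a functional assay on KB cells (Homo sapiens) for antiproliferative activity, read by MTT assay, with a stated time of 48 h; on this read-out lower numbers stand for stronger inhibition and higher numbers for weaker inhibition:
compound 1, `CN(C)C(=O)N(Cc1ccco1)Cc1cc(Cl)ccc1O`, gives 49500 nM
compound 2, `CCOC(=O)N1CCC(N(Cc2ccc(O)cc2)C(=O)N(C)C)CC1`, gives 48600 nM
compound 3, `CCOC(=O)N1CCC(N(Cc2ccc([N+](=O)[O-])cc2)C(=O)N(C)C)CC1`, gives 16400 nM

Compound 1 stands at the highest of the three numbers in this assay. Its nearest neighbour is compound 2, whose number lies within the scatter of that of compound 1, so no order between the two can be stated. Compound 3 sits further off, and the step of a 3.0-fold lower number from compound 2 to compound 3 (0.47 log units; beyond the scatter) shows that this difference is real.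

Compound 4, `CN(C)C(=O)N(Cc1ccco1)Cc1cc(Br)ccc1O`, differs from compound 1 by bromo in place of chloro on an aromatic carbon. For the measured compounds named here, no measured step concerns a halogen exchange: the only measured step, a 3.0-fold lower number from compound 2 to compound 3 (0.47 log units; beyond the scatter), replaces a hydroxy group on a different core with a nitro group and does not bear on a change of chloro to bromo. With nothing to go on beyond the value of compound 1, the expected outcome in this assay is no step beyond the scatter, a 1.1-fold lower number from compound 1 to compound 4 (0.04 log units; within the scatter). Compound 4 is therefore estimated at 45000 nM, with a range from 20000 nM to 100000 nM.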

Compound 4, half-maximal inhibitory concentration: 32800 nM
Compound 4: the middle estimate sits 1.4-fold (0.14 log units) above what was measured; the measured number falls inside the stated range.
By their numbers in this assay, from the lowest: compounds 3, 4, 2 and 1 (each within the scatter of the next, the first and the last beyond it).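

In this assay, the change of chloro to bromo gives a 1.5-fold lower number from compound 1 to compound 4 (0.18 log units; within the scatter) and so stays within the usual scatter. This is the first halogen exchange among the compounds shown, and it indicates that, at this place on the shared core, meta to a large group and para to a hydroxy group, bromo can stand in for chloro with no change that can be told from the scatter. No measurement is available that bears on this outcome or explains it.

The compounds shown leave open whether fluoro, iodo, a methyl group or an amine at this place would also leave the number within the scatter. On these data alone, it also remains open whether nitro in place of the hydroxy group on the core of compound 1 would give a step like a 3.0-fold lower number from compound 2 to compound 3 (0.47 log units; beyond the scatter) on that core.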